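Removing a ring methyl from a dipeptidyl peptidase 4 series

The compounds below may be only part of what the source reports. "The series", "measured", "known", "first", "only" and "open" are said of these compounds alone.

Measured compounds:
Compound 1 `C[C@@H]1N[C@H](C(=O)N2CCC[C@H]2C#N)C[C@@H]1C(=O)N1CCC1`: 94%
Compound 2 `CCCNC(=O)[C@@H]1CN[C@H](C(=O)N2CCC[C@H]2C#N)C1`: 59%
Compound 3 `CCN(C)C(=O)[C@H]1C[C@@H](C(=O)N2CCC[C@H]2C#N)N[C@H]1C`: 92%

In an assay on the whole organism (plasma, strain Sprague-Dawley) for inhibition of Dipeptidyl peptidase 4 (Rattus norvegicus), with a stated time of 6 h, at a dose of 1 mg/kg by the oral route (a lower number here means less inhibition, a higher number more inhibition at the dose given (going by the name of the read-out)), compound 3 gives 92%. Among the three measured numbers it stands second highest. Its nearest neighbour is compound 1, with a step of a number 2 percentage points lower from compound 1 to compound 3 (within the scatter) that lies within the scatter, so the two cannot be ordered. Within the data shown here, its furthest neighbour is compound 2, whose value is lower by a margin beyond the scatter; compound 2 differs from compound 3 in two places at once, so no single step connects them.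

Compound 4 `CCN(C)C(=O)[C@@H]1CN[C@H](C(=O)N2CCC[C@H]2C#N)C1` has not been measured. It differs from compound 3 by hydrogen in place of methyl on a saturated ring carbon. Among the measured compounds shown here, the only single-point step recorded, the one between compound 1 and compound 3, concerns the carbamoyl substituent, not the ring methyl, so it does not bear on this change. For the measured compounds named here, the data hold no step that isolates the methyl. Compound 2, which lacks the methyl but also carries a different carbamoyl group, shows the lowest value of the set, which gives a loose hint that the number may fall. The step from compound 3 to compound 4 is therefore expected to be a number 17 percentage points lower from compound 3 to compound 4 (beyond the scatter), downward but uncertain. Compound 4 is estimated at 75%, within 50% to 92%.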

Compound 4, a percentage reported as inhibition, in the whole organism at one dose (the size of the read-out at that dose, not a potency): 71%
Estimate against measurement, compound 4: 4 percentage points above, and the stated range covers the measured number.
By their numbers in this assay, from the lowest: compound 2; then compound 4; then compounds 3 and 1 (each within the scatter of the next).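

In this assay, among these compounds, the replacement of methyl by hydrogen on the saturated ring carbon gives a number 21 percentage points lower from compound 3 to compound 4 (beyond the scatter), the first step that isolates this position, with the ethyl(methyl)carbamoyl group held constant. Among the compounds shown here, the carbonyl substituent also registers once the methyl is absent, with ethyl(methyl)amino in place of propylamino giving a number 12 percentage points higher from compound 2 to compound 4 (beyond the scatter), whereas the one substituent step among the methyl-bearing compounds, a different replacement, gives a number 2 percentage points lower from compound 1 to compound 3 (within the scatter), so the two steps do not show whether the methyl changes how much the substituent counts. Nothing measured here accounts for either new step.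

The compounds shown leave open whether removing the methyl costs as much when the carbonyl carbon carries azetidin-1-yl, since the methyl-free counterpart of compound 1 is not among them. They also leave open what an ethyl group or a hydroxymethyl group would do on this ring carbon, next to the ring nitrogen, and whether the step seen with a single oral dose and a single time point reflects potency at all.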